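Cyclohexyl for isobutyl on the aryl nitrogen of compound 1

A few compounds are considered here, and "the series" means these few. Any claim that something is new, unique, unknown or untested is made for them only; others in the source may bear on it.

Measured compounds:
compound 1 `CC(C)CN(NC(=O)C1CCC2(CC1)OOC1(OO2)C2CC3CC(C2)CC1C3)c1nc(C#N)ncc1Br`: > 100000 nM
compound 2 `CC(C)CN(NC(=O)C1CCC2(CC1)OOC1(OO2)C2CC3CC(C2)CC1C3)c1cc(Cl)nc(C#N)n1`: > 100000 nM
compound 3 `CC(C)CN(NC(=O)C1CCC2(CC1)OOC1(OO2)C2CC3CC(C2)CC1C3)c1nc(C#N)ncc1Cl`: > 100000 nM

In an ADME assay on HEK-293T cells (Homo sapiens) for cytotoxicity (a lower number here means that less compound is tolerated, a higher number that more compound is tolerated), compound 1 gives only a limit, > 100000 nM, not a number. Compound 2 likewise sits at a limit. Compound 3 also sits at a limit. All three values sit at the limit of > 100000 nM in this assay, at which 3 of the 3 values shown sit, so compound 1 cannot be placed relative to the others.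

Compound 4 `N#Cc1ncc(Br)c(N(NC(=O)C2CCC3(CC2)OOC2(OO3)C3CC4CC(C3)CC2C4)C2CCCCC2)n1` differs from compound 1 by cyclohexyl in place of isobutyl on a nitrogen on an aromatic ring.

Within the data shown here, none of the measured steps touches this position. The steps from compound 1 to compound 2 (a step that the two limits leave unreadable from compound 1 to compound 2), from compound 1 to compound 3 (a step that the two limits leave unreadable from compound 1 to compound 3) and from compound 2 to compound 3 (a step that the two limits leave unreadable from compound 2 to compound 3) are all unreadable, since both ends sit at the limit. Among the measured compounds shown here, no measured step therefore bears on the change from isobutyl to cyclohexyl, and no step beyond the scatter is expected in this assay; the expected step from compound 1 to compound 4 is a step that the limit leaves unreadable from compound 1 to compound 4.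

Compound 4 is estimated at 150000 nM, within 60000 nM to 400000 nM, most likely again only a limit.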

Compound 4, half-maximal cytotoxic concentration: > 100000 nM
Compound 4: only a limit was reported; the forecaster's own chance of this, stated with the estimate: 85%; the middle value is on the limit's open side.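

In this assay compound 4 gives > 100000 nM, a limit and not a number. The change from isobutyl to cyclohexyl between compound 1 and compound 4 therefore cannot be read: the limit of > 100000 nM in this assay, at which 4 of the 4 values shown sit.

The compounds shown leave open how compounds 1 to 4 compare in cytotoxicity, since none has a numerical value.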